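The compounds below may be only part of what the source reports. "The series", "measured", "known", "first", "only" and "open" are said of these compounds alone.

Compound 1 `COc1cccc(-c2c(S(=O)(=O)c3ccc(OC)c(Cl)c3)cnc3cc(F)ccc23)c1` gives 1.71 mL/min in an ADME assay on microsomes from liver (Homo sapiens) for metabolic stability, tested at 2.5 uM; a higher number here means faster removal of the compound, a lower number slower removal.
Compound 2 `COc1cccc(-c2c(S(=O)(=O)c3cccc(C#N)c3)cnc3cc(F)ccc23)c1` gives 1.83 mL/min in this assay.
Compound 3 `O=S(=O)(c1ccc(F)c(F)c1)c1cnc2cc(F)ccc2c1-c1cccc(F)c1` gives 0.6 mL/min in this assay.

Compound 3 stands lowest of the three numbers in this assay; compound 1 and compound 2 both sit higher, beyond the scatter. Compound 4 `COc1cccc(-c2c(S(=O)(=O)c3ccc(F)c(F)c3)cnc3cc(F)ccc23)c1` is compound 3 with one change: methoxy in place of fluoro on an aromatic carbon. After this change compound 4 carries the same 3-methoxyphenyl as compound 1 and compound 2, differing from them only in the group on the sulfonyl sulfur. Among the compounds with values here, the only measured step, a 1.1-fold higher number from compound 1 to compound 2 (0.03 log units; within the scatter), shows that swapping that sulfonyl group left the number essentially unchanged. The gap between compound 3 and the two methoxy compounds is therefore expected to come largely from the methoxy group itself, so compound 4 is expected to move upward toward compound 1 and compound 2, giving an expected step of a 2.5-fold higher number from compound 3 to compound 4 (0.40 log units; beyond the scatter). The estimate for compound 4 in this assay is 1.5 mL/min, with a range from 0.8 mL/min to 2.6 mL/min.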

Compound 4, intrinsic clearance in a liver preparation (reported as CLH), per the amount of preparation that the assay uses: 1.77 mL/min
Beside the measured number, compound 4's estimate is 1.2-fold (0.07 log units) below it; low and high end bracket the measured number.
By their numbers in this assay, from the lowest: compound 3; then compounds 1, 4 and 2 (each within the scatter of the next).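

Among these compounds, the change from 3-fluorophenyl to 3-methoxyphenyl is the first single change to move the number in this assay beyond the scatter, with a 3.0-fold higher number from compound 3 to compound 4 (0.47 log units; beyond the scatter) as its step. Once the 3-methoxyphenyl is in place, exchanging the group on the sulfonyl sulfur leaves the number within the scatter, as both a 1.0-fold higher number from compound 1 to compound 4 (0.01 log units; within the scatter) and a 1.0-fold lower number from compound 2 to compound 4 (0.01 log units; within the scatter) show. Nothing available explains why the fluoro-to-methoxy change gives this step.

Only fluoro and methoxy are shown at this place on the ring, so what a hydroxyl, an amine or a longer alkoxy chain would give remains open. Also open is whether this change would give a similar step with other groups on the sulfonyl sulfur, as compound 3 is the only 3-fluorophenyl compound shown.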